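The source may report more compounds than this note shows. Statements on the series, on what has been measured and on what is new or still open speak of the compounds shown alone.

Measured compounds:
Compound 1, `COc1cc2oc(-c3cccc(NC(=O)c4ccccc4)c3)cc(=O)c2c(OC)c1OC` — 12100 nM
Compound 2, `COc1cc2oc(-c3cccc(NC(=O)c4ccc(Br)cc4)c3)cc(=O)c2c(OC)c1OC` — 9650 nM
Compound 3, `COc1cc2oc(-c3cccc(NC(=O)c4ccc(Cl)cc4)c3)cc(=O)c2c(OC)c1OC` — 8780 nM

All three values come from a functional assay on MCF7 cells (Homo sapiens) for inhibition, read by MTT assay; a higher number here means a weaker inhibitor of growth, a lower number a stronger inhibitor of growth. Compound 3 gives the smallest of the three numbers, yet this standing rests on a 1.4-fold lower number from compound 1 to compound 3 (0.14 log units; within the scatter) and a 1.1-fold lower number from compound 2 to compound 3 (0.04 log units; within the scatter), both within the scatter, so the three compounds are not separated by this assay.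

Compound 4, `COc1cc2oc(-c3cccc(NC(=O)c4ccc(C#N)cc4)c3)cc(=O)c2c(OC)c1OC`, differs from compound 3 in one place: cyano in place of chloro on an aromatic carbon. The measured steps that bear on this change are those in which the same aromatic carbon is varied, namely a 1.3-fold lower number from compound 1 to compound 2 (0.10 log units; within the scatter), a 1.4-fold lower number from compound 1 to compound 3 (0.14 log units; within the scatter) and a 1.1-fold lower number from compound 2 to compound 3 (0.04 log units; within the scatter). Each of them stays within the scatter, so the data give no sign that a group at this position moves the number much. For the measured compounds named here, no step with a cyano group exists among the measured compounds, so the expectation is simply one of no change beyond the scatter. Compound 4 is therefore expected to give about 9000 nM, with a range from 4500 nM to 18000 nM. The estimated step of a 1.0-fold higher number from compound 3 to compound 4 (0.01 log units; within the scatter) is expected to remain within the scatter.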

Compound 4, concentration for 50% growth inhibition: 12700 nM
Estimate against measurement, compound 4: 1.4-fold (0.15 log units) below; low and high end bracket the measured number.
By their numbers in this assay, from the lowest: compounds 3, 2, 1 and 4 (each within the scatter of the next).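

Replacing chloro with cyano on this aromatic carbon, para to a large group, gives a 1.4-fold higher number from compound 3 to compound 4 (0.16 log units; within the scatter) and replacing bromo gives a 1.3-fold higher number from compound 2 to compound 4 (0.12 log units; within the scatter) and replacing hydrogen gives a 1.0-fold higher number from compound 1 to compound 4 (0.02 log units; within the scatter) so this assay does not separate cyano from any of the three earlier groups. Cyano brings a triple bond and a hydrogen-bond acceptor, neither of which the earlier groups carry, and still no step at this position leaves the scatter. Nothing available explains this result.

Whether any group at this position can move the number beyond the scatter remains open, for the compounds shown carry only hydrogen, bromo, chloro and cyano here. An amine, a carboxylic acid or a longer chain in this place would test that further.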